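Chloro for methoxy on the oxime analogue

The source may report more compounds than this note shows. Statements on the series, on what has been measured and on what is new or still open speak of the compounds shown alone.

Compound 1 `COc1ccc(C(=O)CSc2nc3c([nH]2)c(=O)n(C)c(=O)n3C)cc1`: 7600 nM
Compound 2 `Cn1c(=O)c2[nH]c(SCC(=O)c3ccc(Cl)cc3)nc2n(C)c1=O`: 8400 nM
Compound 3 `COc1ccc(/C(CSc2nc3[nH]c(=O)n(C)c(=O)c3[nH]2)=N\O)cc1`: 1800 nM

All three measured compounds were run in a functional assay on MCF7 cells (Homo sapiens) for inhibition, read by MTT assay, with a stated time of 48 h; a lower number here means a stronger inhibitor, a higher number a weaker inhibitor. Among the compounds with values here, compound 1 gives 7600 nM and compound 2 gives 8400 nM; the single change between them, (chloro in place of methoxy on an aromatic carbon), made a step of a 1.1-fold higher number from compound 1 to compound 2 (0.04 log units; within the scatter). Compound 3 gives 1800 nM, the lowest of the three numbers, and its gaps to compound 1 and to compound 2 both lie beyond the scatter. The difference between the core of compound 3 and the core of compound 1 is not broken down here.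

Compound 4 `Cn1c(=O)[nH]c2nc(SC/C(=N/O)c3ccc(Cl)cc3)[nH]c2c1=O` has not yet been measured in this assay. It differs from compound 3 by chloro in place of methoxy on an aromatic carbon, the same change, at the same place, that turned compound 1 into compound 2. Because the earlier step measured a 1.1-fold higher number from compound 1 to compound 2 (0.04 log units; within the scatter), the step from compound 3 to compound 4 is expected to be similarly small: a 1.1-fold higher number from compound 3 to compound 4 (0.05 log units; within the scatter). Compound 4 is therefore estimated at 2000 nM, expected to fall between 900 nM and 4500 nM.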

Compound 4, half-maximal inhibitory concentration: 1400 nM
Estimate against measurement, compound 4: 1.4-fold (0.15 log units) above, within the range that was stated.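

In this assay, putting chloro in place of methoxy on the core of compound 3 gave a 1.3-fold lower number from compound 3 to compound 4 (0.11 log units; within the scatter). Set beside the earlier step on the core of compound 1, the same change behaved alike on both cores: the same change on two cores in this assay, a 1.1-fold higher number (0.04 log units; within the scatter) from compound 1 to compound 2 and a 1.3-fold lower number (0.11 log units; within the scatter) from compound 3 to compound 4, 1.4-fold (0.15 log units) apart, within the scatter of two such steps This shows that, in these two pairs, the swap from 4-methoxyphenyl to 4-chlorophenyl carried over from one core to the other with no step beyond the scatter, but it does not show that the change would behave this way on any further core, in any other assay, or that any other group would carry over as this one did.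

The compounds shown leave open how an amine or a carboxylic acid at the same place on the aromatic ring would fare on either core. They also leave open what a longer chain there would do, and which part of the difference between the core of compound 1 and the core of compound 3 goes with the gap between their values.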